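This account rests on a few compounds, and the source may have more. Where it says the series, first, only, none or still open, it means among the compounds named here.

Series notes. Within the data shown here, compound 3 `O=C(/C(=C/c1ccccc1)CCl)c1ccccc1` gives 3600 nM in a functional assay on SW1573 cells (Homo sapiens) for inhibition, read by sulforhodamine B assay, with a stated time of 48 h (on this read-out lower numbers stand for stronger inhibition of growth and higher numbers for weaker inhibition of growth), the lowest of the three numbers measured so far. Compound 1 `O=C(/C=C/c1ccc(Cl)cc1Cl)c1ccccc1` gives 12000 nM in this assay, and compound 2 `O=C(/C(=C/C1CCCCC1)CCl)c1ccccc1` gives 23000 nM in this assay. Among the measured compounds shown here, the only single-point step recorded is a 6.4-fold lower number from compound 2 to compound 3 (0.81 log units; beyond the scatter); it concerns the exchange of the ring on the double-bonded chain carbon, not substitution on an aromatic carbon.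

Compound 4 `O=C(/C(=C/c1ccc(Cl)cc1)CCl)c1ccccc1` differs from compound 3 by chloro in place of hydrogen on an aromatic carbon. For the measured compounds named here, no measured pair isolates a chloro on an aromatic carbon. Going by the values given here, compound 1 does carry chlorines on its aromatic ring, but it differs from compound 3 in more than one place, so the two values show only that several changes together give a higher number for compound 1; they say nothing about the chloro alone. Among the compounds with values here, with no measured step that speaks to this change, the step expected in this assay is a 1.2-fold lower number from compound 3 to compound 4 (0.08 log units; within the scatter), none beyond the scatter, and the range is kept wide to reflect the missing precedent. Compound 4 is therefore estimated at 3000 nM in this assay, with a range from 1000 nM to 9000 nM.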

Compound 4, concentration for 50% growth inhibition: 3900 nM
For compound 4 the middle estimate is 1.3-fold (0.11 log units) below the measured one, within the range that was stated.
By their numbers in this assay, from the lowest: compounds 3 and 4 (each within the scatter of the next); then compounds 1 and 2 (each within the scatter of the next).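

In this assay, among these compounds, chloro in place of hydrogen on an aromatic carbon, para to a large group, gives a 1.1-fold higher number from compound 3 to compound 4 (0.03 log units; within the scatter), and this is the only pair that isolates that change. Compound 3 and compound 4 cannot be told apart on this read-out, so at this one place on the six-membered aromatic ring, a single chloro leaves the growth-inhibition number within the usual scatter, something the multiple differences between compound 1 and compound 3 could not show. No accompanying measurement bears on this result, and the notes offer no explanation for it.

The compounds shown leave open whether this place tolerates groups other than chloro in the same way, such as a methoxy group, an amine or a carboxylic acid, since a single atom exchange says nothing about them. Also open, on these data alone, is whether chloro on a different aromatic carbon of the ring, or on the other aromatic ring of the shared core, would stay within the scatter of compound 3 as well.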